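From 3-Bromophenyl to 4-Bromophenyl on the Ether Oxygen

The compounds below may be only part of what the source reports. "The series", "measured", "known", "first", "only" and "open" are said of these compounds alone.

Compound 1, `Cc1ccc(OCCCON2C(N)=NC(N)=NC23CCOCC3)cc1`: > 90%
Compound 2, `NC1=NC2(CCOCC2)N(OCCCOc2cccc(Br)c2)C(N)=N1`: 86.7%

Both compounds were tested in an assay on isolated protein for inhibition of Dihydrofolate reductase (Homo sapiens), read by spectrophotometry, using NADPH, with stated times of 5 s and 6 min, tested at 5 uM; a lower number here means a weaker effect, a higher number a stronger effect of the compound at the concentration tested. For compound 1 the reading of > 90% is a limit of the assay and not a number. Compound 2 gives 86.7% in this assay. Among the measured compounds shown here, the single measured step, a number at least 3.3 percentage points lower from compound 1 to compound 2 (that floor lies within the scatter), rests on the limit of > 90% in this assay, at which 1 of the 2 values shown sits, for its floor. For the measured compounds named here, compound 2 therefore stands as the only numbered value in this set; the other value shown is a limit.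

Compound 3, `NC1=NC2(CCOCC2)N(OCCCOc2ccc(Br)cc2)C(N)=N1`, differs from compound 2 in one place: 4-bromophenyl in place of 3-bromophenyl on an oxygen on a saturated carbon. Going by the values given here, no measured step exchanges 3-bromophenyl for 4-bromophenyl. Among the compounds with values here, the only step available, a number at least 3.3 percentage points lower from compound 1 to compound 2 (that floor lies within the scatter), replaced the whole aryl group and stayed within the scatter, which gives no ground to expect a larger movement for a smaller change. Compound 3 is therefore expected to show a step of a number 0.3 percentage points higher from compound 2 to compound 3 (within the scatter) in this assay, nothing beyond the scatter. Compound 3 is estimated at 87%, with a range from 75% to 95%.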

Compound 3, a percentage reported as inhibition, at one concentration (the size of the read-out at that concentration, not a potency): > 90%
Compound 3 gave a limit, no number (the forecaster's own chance of this, stated with the estimate: 30%); middle value at least 3 percentage points from the limit.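

Exchanging 3-bromophenyl for 4-bromophenyl on an oxygen on a saturated carbon, with the same atoms joined differently, gave in this assay a number at least 3.3 percentage points higher from compound 2 to compound 3 (that floor lies within the scatter). Unlike the earlier step, which replaced both the substituent and its place on the aromatic ring, this one tests the place of the bromine alone, and it gives no sign of an effect beyond the scatter. Neither the size of that step nor the step from compound 1 to compound 3 can be fully read, the latter not at all, and no order can be drawn among the three compounds: the limit of > 90% in this assay, at which 2 of the 3 values shown sit.

On these data alone, what remains open is how far compound 1 and compound 3 would separate on a scale that did not end at this limit, and so whether methyl and bromo differ at all on that aromatic carbon. Also open, as far as these compounds go, is whether an amine or a carboxylic acid in place of the bromine, or a longer chain between the two oxygens, would move the read-out further than this shift of the bromine did.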